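The source may hold more compounds than are shown below. What is called first, only, known or untested is meant among the compounds shown, and "the series" means these compounds.

Measured so far:
compound 1 `Cc1cc(Br)cc(OC(c2ccc(Cl)cc2)c2cnc(NC(=O)OC(C)(C)C)s2)c1` — > 50000 nM in an ADME assay on HepG2 2.2.15 cells (Homo sapiens) for cytotoxicity (on this read-out higher numbers stand for lower toxicity in this test and lower numbers for higher toxicity in this test), a limit of the test and not a number
compound 2 `COC(=O)CCCCNc1ncc(C(Oc2ccc3cc(Br)ccc3c2)c2ccc(Cl)cc2)s1` — "not toxic" (no number reported) in this assay

In this assay compound 1 gives only > 50000 nM, which is a limit and not a measured number. Compound 1 thereby supplies (the limit of > 50000 nM in this assay, at which 1 of the 2 values shown sits). In this assay compound 2 is recorded as "not toxic" (no number reported), with no number reported at all. Compound 2 therefore stands with compound 1 at the upper end of what is shown: neither compound has a value inside the measurable range of this test, and nothing separates the two.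

Compound 3 `Cc1ccc(C(=O)Nc2ncc(C(Oc3ccc4cc(Br)ccc4c3)c3ccc(Cl)cc3)s2)cc1` differs from compound 2 in one place: (4-methylphenyl)carbonyl in place of 4-(methoxycarbonyl)butyl on a nitrogen on an aromatic ring. Among the compounds with values here, no measured step bears on this change. The expectation in this assay is no shift beyond the usual scatter, with compound 3 most likely again reported only as a limit. Compound 3 is estimated at 50000 nM, with a range from 20000 nM to 100000 nM.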

Compound 3, half-maximal cytotoxic concentration: "not toxic" (no number reported)
For compound 3 the study gives words and no number, and the estimate cannot be compared.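

In this assay compound 2 gives "not toxic" (no number reported) and compound 3 gives "not toxic" (no number reported), so no step can be read between these two compounds. The compounds shown leave open whether (4-methylphenyl)carbonyl in place of 4-(methoxycarbonyl)butyl shifts the read-out in this assay at all.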